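The compounds below may be only part of what the source reports. "The series", "measured", "known", "first", "only" and "open" are said of these compounds alone.

Measured so far:
- compound 1 `O=C(COCc1ccccc1)N1CCN(c2cccc(Cl)c2)CC1`: 310 mL.min-1.g-1
- compound 2 `O=C(COCc1ccccc1)N1CCN(c2ccc(Cl)cc2)CC1`: 290 mL.min-1.g-1
- compound 3 `O=C(COCc1ccccc1)N1CCN(c2ccc(F)cc2Cl)CC1`: 530 mL.min-1.g-1

In an in vitro ADME assay on microsomes from liver (Homo sapiens) for metabolic stability (on this read-out higher numbers stand for fast clearance and lower numbers for slow clearance), compound 1 stands second highest of the three; compound 2 is nearest with a 1.1-fold lower number from compound 1 to compound 2 (0.03 log units; within the scatter), compound 3 furthest with a 1.7-fold higher number from compound 1 to compound 3 (0.23 log units; within the scatter), and the step of a 1.8-fold higher number from compound 2 to compound 3 (0.26 log units; within the scatter) is likewise within the scatter. All three aryl variations on the shared core therefore read as one level in this assay.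

Compound 4 `O=C(COCc1ccccc1)N1CCN(c2cc(Cl)ccn2)CC1` differs from compound 1 in one place: 4-chloropyridin-2-yl in place of 3-chlorophenyl on an amine nitrogen in a ring. Among the compounds with values here, no measured step exchanges the carbon ring for a ring with a hetero atom, so none bears on it directly; the three aryl steps above are the only guide, and each was within the scatter. The expected step is accordingly small and without a clear direction, a 1.1-fold lower number from compound 1 to compound 4 (0.06 log units; within the scatter), with the range widened for the lack of a direct precedent. Compound 4 is estimated at 270 mL.min-1.g-1, between 120 mL.min-1.g-1 and 600 mL.min-1.g-1.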

Compound 4, intrinsic clearance in microsomes: 130 mL.min-1.g-1
For compound 4 the middle estimate is 2.1-fold (0.32 log units) above the measured one, within the range that was stated.
By their numbers in this assay, from the lowest: compound 4; then compounds 2, 1 and 3 (each within the scatter of the next).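

In this assay, the position on the amine nitrogen in a ring, which gave one level across the three phenyl variations, now gives a second level: 4-chloropyridin-2-yl brings a 2.4-fold lower number from compound 1 to compound 4 (0.38 log units; beyond the scatter), a 2.2-fold lower number from compound 2 to compound 4 (0.35 log units; beyond the scatter) and a 4.1-fold lower number from compound 3 to compound 4 (0.61 log units; beyond the scatter). The entering ring has one hetero atom and one hydrogen-bond acceptor where 3-chlorophenyl has none, and this change of ring type is the only kind of change shown here that gives steps beyond the scatter. No available measurement explains the lower number.

The compounds shown leave open whether the step follows the ring nitrogen itself or its combination with the chlorine. A pyridin-2-yl ring without chlorine, or one carrying a methoxy group or a nitrile instead of the chlorine, would separate the two.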